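The source may report more compounds than this note shows. Statements on the series, on what has been measured and on what is new or still open speak of the compounds shown alone.

Of the compounds shown here, two of a shared core have been tested in a functional assay on ileum for inhibition of histamine H1 receptor (Cavia porcellus); on this read-out higher numbers stand for weaker inhibition and lower numbers for stronger inhibition. Compound 1 `CCSCCCn1c(N2CCN(C)CC2)nc2ccccc21` gives 530 nM in this assay. Compound 2 `COCCn1c(N2CCN(C)CC2)nc2ccccc21` gives 13 nM in this assay, the lowest of the two numbers. For the measured compounds named here, the single step between them, a 41-fold lower number from compound 1 to compound 2 (1.61 log units; beyond the scatter), shows how much this part of the molecule matters.

Compound 3 `CCCC(C)n1c(N2CCN(C)CC2)nc2ccccc21` has not yet been measured. It differs from compound 2 in one place: 1-methylbutyl in place of 2-methoxyethyl on an aromatic nitrogen. The group that leaves carries the only hydrogen-bond acceptor in the chain; the group that enters is all carbon, with one atom more and a branch.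

Going by the values given here, the only step that bears on this change is the one from compound 1 to compound 2, which was large and went toward a lower number when a methoxy group entered. Since compound 3 gives up that oxygen for a plain carbon chain, the expectation is a move in the opposite direction, back toward the number of compound 1, though perhaps not all the way, as the two chains are not alike. The expected step is a 12-fold higher number from compound 2 to compound 3 (1.06 log units; beyond the scatter). Compound 3 is therefore estimated at 150 nM in this assay, within a range from 40 nM to 600 nM.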

Compound 3, half-maximal inhibitory concentration: 1400 nM
For compound 3 the middle estimate is 9.3-fold (0.97 log units) below the measured one; the measured number lies above the stated range.
By their numbers in this assay, from the lowest: compound 2; then compound 1; then compound 3.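

In this assay, this position on the aromatic nitrogen proves even more sensitive than the first pair suggested: replacing 2-methoxyethyl with the all-carbon 1-methylbutyl gives a 110-fold higher number from compound 2 to compound 3 (2.03 log units; beyond the scatter), the largest step seen so far. The comparison with the sulfur-bearing chain gives a 2.6-fold higher number from compound 1 to compound 3 (0.42 log units; beyond the scatter), a modest step but one beyond the scatter, so compound 3 does not simply return to the level of compound 1, and neither chain comes close to compound 2. Nothing available explains why these chains give such different numbers.

The change from compound 2 to compound 3 removes the oxygen and alters both the length and the branching of the chain in a single step, so the compounds shown cannot assign the large rise to any one of these differences. An unbranched pentyl chain would separate branching from the loss of oxygen, while 2-ethoxyethyl or 2-hydroxyethyl would show whether the low number of compound 2 survives when the end of its chain is altered but the oxygen stays.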